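Cyano in place of propylcarbonyl: what compound 4 might give

The source may report more compounds than this note shows. Statements on the series, on what has been measured and on what is new or still open speak of the compounds shown alone.

Measured compounds:
compound 1 `CCOC(=O)c1cnc(NN2C(=O)C=C(C)C2=O)nc1C`: 1900 nM in a functional assay on Jurkat cells (Homo sapiens) for inhibition; on this read-out higher numbers stand for weaker inhibition and lower numbers for stronger inhibition
compound 2 `CCOC(=O)c1cnc(NN2C(=O)C=C(C)C2=O)nc1-c1ccsc1`: 200 nM
compound 3 `CCCC(=O)c1cnc(NN2C(=O)C=C(C)C2=O)nc1CC`: 450 nM

Compound 3 stands second highest of the three numbers in this assay; compound 2 gives a lower number and compound 1 a higher one. Compound 4 `CCc1nc(NN2C(=O)C=C(C)C2=O)ncc1C#N` differs from compound 3 by cyano in place of propylcarbonyl on an aromatic carbon. Among the measured compounds shown here, the only measured step, a 9.5-fold lower number from compound 1 to compound 2 (0.98 log units; beyond the scatter), concerns a different position on the shared core and does not bear on this change; compound 1 and compound 3 differ in two places at once, so their values do not isolate the carbonyl either. For the measured compounds named here, with no directly comparable step, a change of modest size at most is expected in this assay, direction uncertain. Compound 4 is estimated at 600 nM, within 200 nM to 2000 nM. This estimate means an expected 1.3-fold higher number from compound 3 to compound 4 (0.12 log units; within the scatter).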

Compound 4, half-maximal inhibitory concentration: 1100 nM
For compound 4 the middle estimate is 1.8-fold (0.26 log units) below the measured one; the range from low to high includes it.
By their numbers in this assay, from the lowest: compound 2; then compound 3; then compounds 4 and 1 (each within the scatter of the next).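

Among the compounds shown here, the first isolated change at this position, on an aromatic carbon ortho to an ethyl group, gives in this assay a 2.4-fold higher number from compound 3 to compound 4 (0.39 log units; beyond the scatter). Propylcarbonyl, with 5 heavy atoms, therefore gives stronger inhibition here than cyano, with 2, though the step is modest. No measured evidence accounts for this difference. The compounds shown leave open how a longer acyl chain, a carboxylic acid or an amine would read at this position. They also leave open whether cyano gives a similar step when thiophen-3-yl replaces the ethyl group.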